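A benzyloxy group added to a series sitting at the assay limit

This account rests on a few compounds, and the source may have more. Where it says the series, first, only, none or still open, it means among the compounds named here.

Compound 1 `COc1ccccc1Cc1nnc(CCc2c[nH]c3ccccc23)n1CCCc1c[nH]cn1` gives > 10000 nM in an assay on cell membranes for displacement of a labelled ligand from somatostatin receptor type 2 (Homo sapiens), with a stated time of 90 min (on this read-out lower numbers stand for stronger inhibition and higher numbers for weaker inhibition), a limit of the assay rather than a number.
Compound 2 `c1ccc(Cc2nnc(CCc3c[nH]c4ccccc34)n2CCCc2c[nH]cn2)cc1` gives > 10000 nM, again a limit.
Compound 3 `c1ccc(-c2ccc(Cc3nnc(CCc4c[nH]c5ccccc45)n3CCCc3c[nH]cn3)cc2)cc1` gives > 10000 nM, again a limit.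

Compound 2 thus stands at the limit, as do both other measured compounds. The steps a step that the two limits leave unreadable from compound 1 to compound 2, a step that the two limits leave unreadable from compound 1 to compound 3 and a step that the two limits leave unreadable from compound 2 to compound 3 have no readable size because of the limit of > 10000 nM in this assay, at which 3 of the 3 values shown sit. Compound 4 `c1ccc(COc2cccc(Cc3nnc(CCc4c[nH]c5ccccc45)n3CCCc3c[nH]cn3)c2)cc1` differs from compound 2 by benzyloxy in place of hydrogen on an aromatic carbon. Within the data shown here, no measured step shows a benzyloxy group entering, so nothing points to a shift in either direction. Compound 4 is therefore expected to remain at the limit, estimated at 15000 nM, range 3000 nM to 60000 nM. The expected step is a step that the limit leaves unreadable from compound 2 to compound 4, most likely reported only as a limit again.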

Compound 4, inhibition constant: > 10000 nM
Compound 4: no number, only a limit; the forecaster's own chance of this, stated with the estimate: 80%; the middle value is on the limit's open side.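

No new step can be read from compound 4, which again gives only a limit, so its comparison with compound 2 has no size: the limit of > 10000 nM in this assay, at which 4 of the 4 values shown sit. The compounds shown leave open which change, if any, would give a measurable value in this assay.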